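The source may report more compounds than this note shows. Statements on the series, on what has been measured and on what is new or still open speak of the compounds shown alone.

In an assay on isolated protein for binding affinity to Gonadotropin-releasing hormone receptor (Homo sapiens) (on this read-out lower numbers stand for stronger inhibition and higher numbers for weaker inhibition), compound 2 `Cc1cc2c(cc1Cc1ccc(C(=O)NCc3ccc(CN)cc3)o1)C(C)(C)CCC2(C)C` gives 140 nM. Going by the values given here, the only other measured compound, compound 1 `Cc1ccc(CNC(=O)c2ccc(Cc3cc4c(cc3C)C(C)(C)CCC4(C)C)o2)cc1`, gives 83 nM in this assay, and the step of a 1.7-fold higher number from compound 1 to compound 2 (0.23 log units; within the scatter) stays within the scatter. Compound 3 `Cc1cc2c(cc1Cc1ccc(C(=O)NCc3ccccc3)o1)C(C)(C)CCC2(C)C` differs from compound 2 by hydrogen in place of aminomethyl on an aromatic carbon. Among the compounds with values here, the single measured step that bears on this change, a 1.7-fold higher number from compound 1 to compound 2 (0.23 log units; within the scatter), touched the same benzyl group and moved the number only within the scatter, so no shift beyond the scatter is expected here either. Compound 3 is therefore estimated at about 100 nM, within 40 nM to 250 nM, an expected step of a 1.4-fold lower number from compound 2 to compound 3 (0.15 log units; within the scatter).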

Compound 3, inhibition constant: 102 nM
Compound 3: the middle estimate sits 1.0-fold (0.01 log units) below what was measured; the measured number falls inside the stated range.
By their numbers in this assay, from the lowest: compounds 1, 3 and 2 (each within the scatter of the next).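

Compound 3 adds the unsubstituted benzyl group, so each of the two groups at this place on the ring can now be compared with plain hydrogen. Replacing aminomethyl with hydrogen gives a 1.4-fold lower number from compound 2 to compound 3 (0.14 log units; within the scatter), and replacing methyl with hydrogen gives a 1.2-fold higher number from compound 1 to compound 3 (0.09 log units; within the scatter). Hydrogen, methyl and aminomethyl at this place therefore cannot be told apart in this assay. On these data alone, whether a carboxylic acid, a chlorine atom or a longer chain here would shift the number beyond the scatter remains open. Nothing available explains why these three compounds read alike.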